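A few compounds are considered here, and "the series" means these few. Any claim that something is new, unique, unknown or untested is made for them only; others in the source may bear on it.

Of the compounds shown here, two from this series have been measured in a functional assay on A549 cells (Homo sapiens) for inhibition, read by sulforhodamine B assay, with a stated time of 72 h; on this read-out higher numbers stand for weaker inhibition of growth and lower numbers for stronger inhibition of growth. Compound 1 `CC(C)(C)OC(=O)NCCCCCN1C(Nc2ccc(-c3ccccc3)cc2)=Nc2ccccc2C1CC(=O)NCc1ccccc1` gives 1870 nM. Compound 2 `O=C(CC1c2ccccc2N=C(N2CCCCC2)N1c1ccccc1)NCc1ccc(NS(=O)(=O)c2ccc(F)cc2)cc1` gives 1930 nM, and on this read-out compound 2 and compound 1 sit so close together that the gap between them lies within the usual scatter of repeated measurements, so the two numbers cannot be told apart.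

Compound 3 `CCN1C(N2CCCCC2)=Nc2ccccc2C1CC(=O)NCc1ccc(NS(=O)(=O)c2ccc(F)cc2)cc1` has not yet been measured. It is compound 2 with one change: ethyl in place of phenyl on an amine nitrogen in a ring. Within the data shown here, no pair of measured compounds shows a comparable exchange, so nothing in the numbers so far tells how large this step will be or which way it will go. The working expectation is a modest rise in the concentration for half-maximal growth inhibition, of about a 2.1-fold higher number from compound 2 to compound 3 (0.32 log units; beyond the scatter), possibly beyond the scatter but not by much. On that basis, compound 3 is expected to give about 4000 nM in this assay, with a plausible range from 1200 nM to 15000 nM.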

Compound 3, concentration for 50% growth inhibition: 24500 nM
The estimate for compound 3 lay 6.1-fold (0.79 log units) below the measured number; measured number above the stated range.
By their numbers in this assay, from the lowest: compounds 1 and 2 (each within the scatter of the next); then compound 3.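

Among these compounds, this is the first measured exchange at this ring nitrogen, and it shows that the position is sensitive to what it carries: in this assay, putting ethyl in place of phenyl gives a 13-fold higher number from compound 2 to compound 3 (1.10 log units; beyond the scatter), a large move toward weaker inhibition of growth. Only this one place differs between the two compounds, so the whole step belongs to losing the six-membered aromatic ring and gaining a two-carbon group with no ring. Nothing measured here explains why the step is so large.

One exchange cannot show whether the aromatic ring itself matters or whether any larger group would serve equally well. A cyclohexyl ring, a benzyl group or a butyl chain on this nitrogen would help separate those two readings.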